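Working notes: adding methoxy to compound 2

The source may hold more compounds than are shown below. What is called first, only, known or untested is meant among the compounds shown, and "the series" means these compounds.

Measured so far in a functional assay on A549 cells (Homo sapiens) for cytotoxicity, read by MTT assay, with a stated time of 72 h; on this read-out lower numbers stand for stronger inhibition and higher numbers for weaker inhibition:
- compound 1 `CCCC[S+]([O-])CCCCN=C=S` gives 9560 nM
- compound 2 `[O-][S+](CCCCN=C=S)Cc1ccccc1` gives 7410 nM

Compound 2 (7410 nM) lies within the scatter of compound 1 (9560 nM), so neither stands apart on these numbers. Compound 3 `COc1ccc(C[S+]([O-])CCCCN=C=S)cc1` follows from compound 2 through one change, (methoxy in place of hydrogen on an aromatic carbon), in words methoxy in place of hydrogen on an aromatic carbon, para to a large group. Among the measured compounds shown here, no measured pair shows this change, so no step beyond the scatter is expected in this assay. The expected step is small (a 1.1-fold lower number from compound 2 to compound 3 (0.02 log units; within the scatter)). The expected value for compound 3 is 7000 nM (estimated range 3500 nM to 14000 nM).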

Compound 3, half-maximal inhibitory concentration: 32600 nM
For compound 3 the middle estimate is 4.7-fold (0.67 log units) below the measured one; the measured number lies above the stated range.
By their numbers in this assay, from the lowest: compounds 2 and 1 (each within the scatter of the next); then compound 3.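

In this assay, methoxy in place of hydrogen on an aromatic carbon, para to a large group, gives a 4.4-fold higher number from compound 2 to compound 3 (0.64 log units; beyond the scatter) and so shows that the number responds to a change at this place on the ring. Among the compounds shown here, this is the first step that lies beyond the scatter. Nothing available on these compounds accounts for the step.

From the compounds shown here alone, whether the step belongs to methoxy itself or to any group at this place remains open. A hydroxyl or a fluorine at the same place would help separate these two readings.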